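The source may report more compounds than this note shows. Statements on the series, on what has been measured and on what is new or still open speak of the compounds shown alone.

Compound 1 `O=S(=O)(Nc1ccc(-c2nc3ccccc3o2)cc1)c1cccc(O)c1`: > 63000 nM
Compound 2 `O=S(=O)(Nc1ccc(-c2nc3ccccc3o2)cc1)c1cccs1`: > 63000 nM

Of the compounds shown here, two have been tested in an assay on isolated protein for inhibition of malate dehydrogenase, mitochondrial (Sus scrofa), with stated times of 45 min and 30 min; on this read-out lower numbers stand for stronger inhibition and higher numbers for weaker inhibition. For compound 1 the value > 63000 nM is a limit of the assay and not a number. For compound 2 the value > 63000 nM is likewise a limit. The step that the two limits leave unreadable from compound 1 to compound 2 is therefore not readable in size. For the measured compounds named here, compound 2 thus stands only at a limit, and the numbers do not separate it from compound 1; the single point of evidence is the limit of > 63000 nM in this assay, at which 2 of the 2 values shown sit.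

Compound 3 `C=Cc1ccc(S(=O)(=O)Nc2ccc(-c3nc4ccccc4o3)cc2)cc1` carries 4-vinylphenyl in place of thiophen-2-yl on a sulfonyl sulfur. Going by the values given here, the only measured step that bears on this change is a step that the two limits leave unreadable from compound 1 to compound 2, and it gives no readable size. Compound 3 is therefore expected to behave like compound 2, with an estimated step that the limit leaves unreadable from compound 2 to compound 3 in this assay that does not go beyond the scatter. Compound 3 is thus estimated at 100000 nM, within 30000 nM to 400000 nM.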

Compound 3, half-maximal inhibitory concentration: > 63000 nM
Compound 3: a limit, no number; the forecaster's own chance of this, stated with the estimate: 85%; the middle value is on the limit's open side.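

In this assay compound 3 gives > 63000 nM, a limit of the assay and not a number. Its steps from compound 1 and from compound 2 cannot be read in size. The compounds shown leave open how strongly any of the three inhibits, and whether changing the group on the sulfonyl sulfur alters that.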